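A few compounds are considered here, and "the series" means these few. Any claim that something is new, unique, unknown or untested is made for them only; others in the source may bear on it.

Compound 1 `Cc1cccc(OCCCOc2ccc(CCC(=O)O)cc2)c1C`: > 10000 nM
Compound 2 `CCCCC(Sc1ccc(OCCCOc2cccc(C)c2)cc1)C(=O)O`: 4800 nM
Compound 3 `CCCCC(Sc1ccc(OCCCOc2cccc3c2CCCC3)cc1)C(=O)OCC`: > 10000 nM

Within the data shown here, in an assay on isolated protein for inhibition of Polyunsaturated fatty acid 5-lipoxygenase (Homo sapiens), read by HPLC, with a stated time of 15 min, in the presence of a further agent that is not named here (on this read-out lower numbers stand for stronger inhibition and higher numbers for weaker inhibition), compound 2 gives 4800 nM and is the only compound with a number. For compound 1 the read-out is a limit of the assay, not a number. For compound 3 the read-out is likewise a limit (the limit of > 10000 nM in this assay, at which 2 of the 3 values shown sit). Compound 3 thus stands at that limit, as compound 1 does. Compound 4 `CCCCC(Sc1ccc(OCCCOc2ccc3ncccc3c2)cc1)C(=O)OCC` differs from compound 3 by quinolin-6-yl in place of 1,2,3,4-tetrahydronaphthalen-5-yl on an oxygen on a saturated carbon. Among the measured compounds shown here, no measured pair isolates this change. The step from compound 3 to compound 4 is expected to be a number no higher from compound 3 to compound 4 (the limit leaves the size open), nothing beyond the scatter. Compound 4 is estimated at 10000 nM, between 3000 nM and 30000 nM, with a fair chance that only a limit is reported again.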

Compound 4, half-maximal inhibitory concentration: 800 nM
Compound 4: the middle estimate sits 13-fold (1.10 log units) above what was measured; the whole stated range lies above it.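

The group on this oxygen on a saturated carbon matters in this assay: quinolin-6-yl in place of 1,2,3,4-tetrahydronaphthalen-5-yl gives an at least 12-fold lower number from compound 3 to compound 4 (1.09 log units; beyond the scatter). Compound 4 also shows that a compound carrying the ethyl ester can give a measured number here. The step is a minimum, and its full size stays unknown, as compound 3 sits at a limit of the assay: the limit of > 10000 nM in this assay, at which 2 of the 4 values shown sit.

The change alters both the ring nitrogen and the saturated ring, and a naphthyl group would be needed to separate the two. On these data alone, what a carboxylic acid in place of the ethyl ester would do alongside quinolin-6-yl also remains open.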